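Cytotoxicity notes: compound 2 to compound 3

The compounds below may be only part of what the source reports. "The series", "measured", "known", "first", "only" and "open" are said of these compounds alone.

Compound 2 `COC(=O)c1ccc(NCc2cncn2Cc2cccc(N)c2)cc1-c1ccccc1` gives only a limit in a toxicity assay on NIH3T3 cells (Mus musculus) for cytotoxicity, read by resazurin assay (a higher number here means that more compound is needed for the effect, a lower number that less compound is needed), > 10000 nM. Compound 1 `COC(=O)c1ccc(NCc2cncn2Cc2ccccc2N)cc1-c1ccccc1` gives 25000 nM in this assay. The step that the limit leaves unreadable from compound 1 to compound 2 cannot be sized because of the limit of > 10000 nM in this assay, at which 1 of the 2 values shown sits. Compound 3 `COC(=O)c1ccc(NCc2cncn2Cc2cccc(C(C)(C)C)c2)cc1-c1ccccc1` differs from compound 2 by tert-butyl in place of amino on an aromatic carbon. Among the compounds with values here, no measured step bears on this change; the only step in the set is unreadable. Weak cytotoxicity near the limit is expected again, with the expected step that the limit leaves unreadable from compound 2 to compound 3 in this assay not exceeding the scatter. Compound 3 is estimated at 20000 nM in this assay, within 6000 nM to 70000 nM.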

Compound 3, half-maximal effective concentration: > 1000 nM
Compound 3: no number, only a limit; the forecaster's own chance of this, stated with the estimate: 50%; the middle value does not contradict the limit.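

Within the data shown here, compound 3 gives only a limit in this assay, > 1000 nM, so no step from compound 1 or compound 2 to compound 3 can be read. The compounds shown leave open how tert-butyl in place of amino shifts cytotoxicity.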